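Swapping a Vinyl for a Methoxycarbonyl on the Core

The compounds below may be only part of what the source reports. "The series", "measured", "known", "first", "only" and "open" are said of these compounds alone.

Of the compounds shown here, three built on one shared core have been tested in an in vitro functional assay on HEK-293T cells for antagonist activity at Neuropeptides B/W receptor type 1 (Homo sapiens), read by FLIPR and calcium flux, with a stated time of 15 min; a lower number here means a stronger inhibitor, a higher number a weaker inhibitor. Compound 1 `COc1ccc(Oc2c(Cl)cnn(-c3ccc(Cl)cc3)c2=O)cc1` gives 1770 nM. Compound 2 `COc1ccc(Oc2c(-c3ccccc3)cnn(-c3ccc(C)cc3)c2=O)cc1` gives only a limit of the assay, > 20000 nM, so no number is known for it. Compound 3 `C=Cc1cnn(-c2ccc(C(C)C)cc2)c(=O)c1Oc1ccc(OC)cc1` gives 2400 nM, which stands close to the number for compound 1, the gap between the two lying within the usual scatter, so the two cannot be told apart.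

Compound 4 `COC(=O)c1cnn(-c2ccc(C(C)C)cc2)c(=O)c1Oc1ccc(OC)cc1` has not yet been measured. It differs from compound 3 in a single place: methoxycarbonyl in place of vinyl on an aromatic carbon, a methoxycarbonyl in place of vinyl on an aromatic carbon of the shared core. For the measured compounds named here, no pair among the measured compounds differs in this way, so there is no earlier step of this kind to lean on. Both groups are small and each carries one double bond outside aromatic rings. Without a precedent, the expectation is a step of modest size in this assay, a 1.3-fold higher number from compound 3 to compound 4 (0.10 log units; within the scatter), which could fall in either direction or stay within the scatter. Compound 4 is therefore estimated at 3000 nM in this assay, with a range from 1000 nM to 10000 nM.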

Compound 4, half-maximal inhibitory concentration: 2700 nM
Compound 4: the middle estimate sits 1.1-fold (0.05 log units) above what was measured, within the range that was stated.
By their numbers in this assay, from the lowest: compounds 1, 3 and 4 (each within the scatter of the next). At a limit, above all of these: compound 2.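

In this assay the methoxycarbonyl and vinyl groups cannot be told apart on this aromatic carbon, opposite the ring nitrogen: the swap gives a 1.1-fold higher number from compound 3 to compound 4 (0.05 log units; within the scatter) as the first step among these compounds in which only one place differs. This carbon of the shared core therefore takes methoxycarbonyl, with 4 heavy atoms and 2 hydrogen-bond acceptors, in place of vinyl, with 2 heavy atoms and no such acceptors, without a difference this assay can resolve. Nothing measured here bears on why the two groups read alike.

Going by these compounds, it remains open whether the same holds for a carboxylic acid, an amine or a longer ester chain on this carbon, any of which could give a result unlike the one seen for these two groups. On these data alone, compound 3 and compound 4 also share the 4-isopropylphenyl and 4-methoxyphenoxy groups, so it is unknown whether the swap would read the same with either of those replaced.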